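This account rests on a few compounds, and the source may have more. Where it says the series, first, only, none or still open, it means among the compounds named here.

Compound 1 `CN(C)CCn1cnnc1-c1cc(Oc2ccc(NC(=O)N/N=C/c3ccc(O)c(F)c3)cc2F)ccn1` gives 13400 nM in a functional assay on A549 cells (Homo sapiens) for cytotoxicity, read by MTT assay, with a stated time of 72 h (on this read-out higher numbers stand for weaker inhibition and lower numbers for stronger inhibition), the highest of the three numbers measured: compound 2 `CN(C)CCn1cnnc1-c1cc(Oc2ccc(NC(=O)N/N=C/c3cc(C(C)(C)C)cc(C(C)(C)C)c3O)cc2F)ccn1` gives 980 nM and compound 3 `CN(C)CCn1cnnc1-c1cc(Oc2ccc(NC(=O)N/N=C/c3c(O)ccc4ccccc34)cc2F)ccn1` gives 880 nM. Within the data shown here, the only single-point step among them, a 15-fold lower number from compound 1 to compound 3 (1.18 log units; beyond the scatter), shows how much this part of the molecule can matter. Compound 4 `Cc1cc(/C=N/NC(=O)Nc2ccc(Oc3ccnc(-c4nncn4CCN(C)C)c3)c(F)c2)cc(C)c1O` differs from compound 1 by 4-hydroxy-3,5-dimethylphenyl in place of 3-fluoro-4-hydroxyphenyl on a carbon with a double bond to nitrogen. Among the measured compounds shown here, no measured step covers exactly this change; the step from compound 1 to compound 3 and the gap between compound 1 and compound 2 both point to a lower number once the 3-fluoro-4-hydroxyphenyl is replaced, though the group entering compound 4 is neither of those two. A moderate drop beyond the scatter is therefore expected, a 4.5-fold lower number from compound 1 to compound 4 (0.65 log units; beyond the scatter). Compound 4 is estimated at 3000 nM, between 1000 nM and 9000 nM.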

Compound 4, half-maximal inhibitory concentration: 1640 nM
Estimate against measurement, compound 4: 1.8-fold (0.26 log units) above; measured number inside the range.
By their numbers in this assay, from the lowest: compounds 3, 2 and 4 (each within the scatter of the next); then compound 1.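

In this assay the replacement gives an 8.2-fold lower number from compound 1 to compound 4 (0.91 log units; beyond the scatter), so the lower number at this position is also reached with a single methyl-bearing phenyl group. Against 2-hydroxynaphthalen-1-yl, the same group gives a 1.9-fold higher number from compound 3 to compound 4 (0.27 log units; within the scatter), which lies within the scatter and sets neither group ahead of the other. Nothing given here explains the change.

All the groups shown at this position carry a hydroxy group, so it remains open whether the lower number would persist with an amine or a carboxylic acid in its place.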